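A few compounds are considered here, and "the series" means these few. Any claim that something is new, unique, unknown or untested is made for them only; others in the source may bear on it.

Measured compounds in a functional assay on A549 cells (Homo sapiens) for antiproliferative activity, read by MTT assay, with a stated time of 48 h; on this read-out lower numbers stand for stronger inhibition and higher numbers for weaker inhibition:
compound 1, `Cc1ccccc1-n1nncc1CN1C(=O)C2(C(C#N)=C(N)Oc3c(N)cc4nc5ccccc5nc4c32)c2ccccc21`, 31700 nM
compound 2, `CCc1ccccc1-n1nncc1CN1C(=O)C2(C(C#N)=C(N)Oc3c(N)cc4nc5ccccc5nc4c32)c2ccccc21`, 24600 nM
compound 3, `Cc1ccc(-n2nncc2CN2C(=O)C3(C(C#N)=C(N)Oc4c(N)cc5nc6ccccc6nc5c43)c3ccccc32)cc1C`, > 50000 nM, a limit of the assay and not a number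

Compound 3 stands at the top of the numbers shown. Among the compounds with values here, its entry is a limit of the assay, not a measured number, and it is the one compound of the three that sits there (the limit of > 50000 nM in this assay, at which 1 of the 3 values shown sits). Compounds 1 and 2, which carry 2-methylphenyl and 2-ethylphenyl on the aromatic nitrogen, lie within the scatter of each other, a 1.3-fold lower number from compound 1 to compound 2 (0.11 log units; within the scatter). Going to the 3,4-dimethylphenyl compound gives an at least 1.5-fold higher number from compound 1 to compound 3 (0.19 log units; that floor lies within the scatter) and an at least 2.0-fold higher number from compound 2 to compound 3 (0.30 log units; that floor lies within the scatter); both are floors within the scatter, so no move beyond scatter is established for a change of the phenyl substitution pattern.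

Compound 4, `Cc1cc(C)c(-n2nncc2CN2C(=O)C3(C(C#N)=C(N)Oc4c(N)cc5nc6ccccc6nc5c43)c3ccccc32)c(C)c1`, is not yet measured in this assay. It differs from compound 3 by 2,4,6-trimethylphenyl in place of 3,4-dimethylphenyl on an aromatic nitrogen. Within the data shown here, the steps that bear on it are the two just named, which only set floors within the scatter. No step beyond the scatter is therefore expected, and the step from compound 3 to compound 4 is estimated as an at least 1.1-fold lower number from compound 3 to compound 4 (0.07 log units; that floor lies within the scatter). Compound 4 is expected near the limit, estimated at 42000 nM with a range of 15000 nM to 120000 nM.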

Compound 4, half-maximal inhibitory concentration: 12700 nM
Compound 4: the middle estimate sits 3.3-fold (0.52 log units) above what was measured; the whole stated range lies above it.
By their numbers in this assay, from the lowest: compounds 4, 2 and 1 (each within the scatter of the next, the first and the last beyond it). At a limit, above all of these: compound 3.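

In this assay, within the data shown here, the aryl group on the aromatic nitrogen now yields a step beyond the scatter, which the earlier steps at this position did not establish: an at least 3.9-fold lower number from compound 3 to compound 4 (0.59 log units; beyond the scatter). The entry for compound 3 remains a limit of the assay and not a number, so this step is known only as a floor: the limit of > 50000 nM in this assay, at which 1 of the 4 values shown sits. The 2,4,6-trimethylphenyl group also clears the scatter against 2-methylphenyl, with a 2.5-fold lower number from compound 1 to compound 4 (0.40 log units; beyond the scatter), but not against 2-ethylphenyl, with a 1.9-fold lower number from compound 2 to compound 4 (0.29 log units; within the scatter), so among these four compounds the change in the phenyl substitution pattern matters for some pairs, and the pair of compound 2 and compound 4 goes against any general gain.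

All the aryl groups shown carry only methyl or ethyl substituents, so it stays open whether a methoxy group, a chlorine atom or an amine on the phenyl ring would give a number on the same scale. Going by these compounds, it also stays open whether a longer chain such as propyl or butyl on this ring would follow 2-ethylphenyl or 2,4,6-trimethylphenyl, or would instead approach the limit seen for compound 3.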